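This account rests on a few compounds, and the source may have more. Where it says the series, first, only, none or still open, it means among the compounds named here.

For the measured compounds named here, in a physicochemical assay for lipophilicity (on this read-out higher numbers stand for higher lipophilicity and lower numbers for lower lipophilicity), compound 1 `CCOC(=O)c1ccc(S(N)(=O)=O)cc1` gives 1.17 and compound 2 `CCCCCOC(=O)c1ccc(S(N)(=O)=O)cc1` gives 2.71, the higher of the two numbers so far. These compounds differ by a propyl in place of hydrogen on a saturated chain carbon, and the result is a number 1.54 log units higher from compound 1 to compound 2 (beyond the scatter). Compound 3 `CCCNC(=O)c1ccc(S(N)(=O)=O)cc1` has not yet been measured. It carries propylamino in place of pentyloxy on a carbonyl carbon. Going by the values given here, only one measured step offers guidance. There, a longer chain came with a higher number, so the shorter chain of compound 3 should give back part of a number 1.54 log units higher from compound 1 to compound 2 (beyond the scatter). Among the compounds with values here, no measured step covers the exchange of oxygen for nitrogen or the hydrogen-bond donor that enters, so a further fall is assumed and the range is kept wide. A large downward step is therefore expected, estimated as a number 1.96 log units lower from compound 2 to compound 3 (beyond the scatter). For compound 3 the estimated value is 0.75, with an expected range from 0.3 to 1.2.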

Compound 3, partition coefficient: 0.51
Estimate against measurement, compound 3: 0.24 log units above; measured number inside the range.
By their numbers in this assay, from the lowest: compound 3; then compound 1; then compound 2.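

At this carbonyl carbon, the number in this assay depends on more than chain length: propylamino in place of pentyloxy gives a number 2.20 log units lower from compound 2 to compound 3 (beyond the scatter) and marks this exchange as a large one. The comparison with the ethoxy compound is more telling, since propylamino in place of ethoxy gives a number 0.66 log units lower from compound 1 to compound 3 (beyond the scatter) even though propyl is the longer chain, so chain length alone cannot account for the change at this position. Nothing available explains why the amide lies lower than either ester.

With only one amide shown, it remains open whether lengthening the chain raises the number in amides as it did in the esters, as a pentylamino group would show. A dimethylamino group, which has no amide hydrogen, would test whether that hydrogen matters.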